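The compounds below may be only part of what the source reports. "The series", "measured", "known", "first", "only" and "open" are said of these compounds alone.

Measured compounds:
Compound 1 `COC(=O)C1=C(C)N=C(C)/C(=C(\O)OC)C1c1ccc(Cl)cc1` gives 8130 nM in a functional assay (muscle tissue) with Cavia porcellus as the target; a higher number here means that more compound is needed for the effect, a lower number that less compound is needed.
Compound 2 `COC(=O)C1=C(C)N=C(C)/C(=C(\O)OC)C1c1cccc(OC(=O)c2ccccc2)c1` gives 6310 nM in this assay.
Compound 3 `COC(=O)C1=C(C)N=C(C)/C(=C(\O)OC)C1c1ccc(Cl)cc1Cl` gives 640 nM in this assay.

Compound 2 stands second highest of the three numbers. Its nearest neighbour is compound 1, within the scatter, while compound 3 lies far below it, beyond the scatter. Compound 4 `COC(=O)C1=C(C)N=C(C)/C(=C(\O)OC)C1c1cccc(N(C)C)c1` arises from compound 2 through (dimethylamino in place of benzoyloxy on an aromatic carbon). Within the data shown here, the only measured step, a 13-fold lower number from compound 1 to compound 3 (1.10 log units; beyond the scatter), concerns a different group on the ring and does not bear on this exchange. Without a step that bears on it, no change beyond the scatter is expected in this assay. Compound 4 is therefore estimated at 6000 nM, with a range from 1500 nM to 25000 nM. The expected step is a 1.1-fold lower number from compound 2 to compound 4 (0.02 log units; within the scatter).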

Compound 4, half-maximal effective concentration: 891 nM
Estimate against measurement, compound 4: 6.7-fold (0.83 log units) above, and the stated range ends above it.
By their numbers in this assay, from the lowest: compounds 3 and 4 (each within the scatter of the next); then compounds 2 and 1 (each within the scatter of the next).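

Exchanging benzoyloxy for dimethylamino at this place, on an aromatic carbon meta to a large group, gives a 7.1-fold lower number from compound 2 to compound 4 (0.85 log units; beyond the scatter) in this assay. Among these compounds, the earlier compounds showed a change beyond the scatter only for a chloro in place of hydrogen, so this is the first sign that the group at this place matters as well. No measurement given here accounts for the step.

The pair cannot separate the loss of the benzoyloxy ring from the arrival of the dimethylamino nitrogen. As far as these compounds go, whether a primary amine or a methoxy group at this place would follow compound 4 or compound 2 remains open.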